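A pyridyl group added to the weakest cyclic urea

The source may hold more compounds than are shown below. What is called first, only, known or untested is meant among the compounds shown, and "the series" means these compounds.

Measured so far:
compound 1, `O=C1NCCN(c2cccc(OCc3ccccc3)c2)N1`, gives 200 nM
compound 2, `CC1CN(c2cccc(F)c2)NC(=O)N1`, gives 1800 nM
compound 3, `O=C1NCCN(c2ccccn2)N1`, gives 8600 nM

In a functional assay on cells for inhibition of Polyunsaturated fatty acid 5-lipoxygenase (Homo sapiens) (on this read-out lower numbers stand for stronger inhibition and higher numbers for weaker inhibition), compound 3 has the highest number of the three, and both steps to the other compounds lie beyond the scatter: compound 2 gives a clearly lower number, and compound 1 a far lower one. Compound 4, `O=C1NCCN(c2cccc(-c3ccccn3)n2)N1`, differs from compound 3 by pyridin-2-yl in place of hydrogen on an aromatic carbon. No measured pair of compounds shows this exact change, so the expected step can only be guessed from the set shown. Because compound 1, which carries a larger group on its aryl ring, gives 200 nM, a gain is expected rather than a loss, though a modest one, as this assay may also register no step beyond the scatter. Compound 4 is therefore expected to give 2500 nM, within a range from 600 nM to 10000 nM, which would mean an expected step of a 3.4-fold lower number from compound 3 to compound 4 (0.54 log units; beyond the scatter).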

Compound 4, half-maximal inhibitory concentration: > 50000 nM
Compound 4 was reported as a limit (the forecaster's own chance of this, stated with the estimate: 5%); middle value at least 20-fold (1.30 log units) away from the limit.
By their numbers in this assay, from the lowest: compound 1; then compound 2; then compound 3. At a limit, above all of these: compound 4.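

In this assay, pyridin-2-yl in place of hydrogen on this aromatic carbon, next to the ring nitrogen, gives an at least 5.8-fold higher number from compound 3 to compound 4 (0.76 log units; beyond the scatter). Among the compounds shown here, this is the first single-place step in the set, and it runs toward weaker inhibition, so this group brings no gain at this place. Compound 4 stands at a limit, not at a number: the limit of > 50000 nM in this assay, at which 1 of the 4 values shown sits.

As far as these compounds go, whether a methyl group or an amine on this carbon would keep the inhibition of compound 3 stays open. So does the effect of pyridin-2-yl elsewhere on the ring.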